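Working notes: from compound 2 to compound 3

This account rests on a few compounds, and the source may have more. Where it says the series, first, only, none or still open, it means among the compounds named here.

Measured in an ADME assay on HEK-293T cells (Homo sapiens) for cytotoxicity, read by CCK-8 assay, with a stated time of 48 h; a lower number here means a stronger inhibitor, a higher number a weaker inhibitor:
- compound 1 (`O=C(NCCNS(=O)(=O)c1ccc(-c2ccccc2Oc2ccc([N+](=O)[O-])c([N+](=O)[O-])c2)s1)Nc1ccc([N+](=O)[O-])cc1`): 16600 nM
- compound 2 (`COc1ccc(Oc2ccccc2-c2ccsc2S(=O)(=O)N2CCN(C(=O)Nc3cccc([N+](=O)[O-])c3)CC2)cc1OC`): > 20000 nM (a limit)

Compound 2 reports only a limit (> 20000 nM) and no number. Compound 3 (`COc1ccc(Oc2ccccc2-c2ccsc2S(=O)(=O)N2CCN(C(=O)Nc3ccc(F)cc3)CC2)cc1OC`) differs from compound 2 in one place (4-fluorophenyl in place of 3-nitrophenyl on an amide-type nitrogen), with 4-fluorophenyl in place of 3-nitrophenyl on an amide-type nitrogen. Within the data shown here, no measured pair covers this change, so the expected step (a step that the limit leaves unreadable from compound 2 to compound 3) is none beyond the scatter, in either direction. Among the measured compounds shown here, compound 1 gives the only number so far (16600 nM) and offers a rough guide to the range. In this assay the estimated value for compound 3 is 24000 nM (expected range 12000 nM to 45000 nM).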

Compound 3, half-maximal inhibitory concentration: > 50000 nM
Compound 3: a limit, no number; the forecaster's own chance of this, stated with the estimate: 60%; middle value at least 2.0-fold (0.31 log units) away from the limit.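

Compound 2 and compound 3 each report only a limit, so no step can be read between them. The compounds shown leave open the actual value of either compound, and whether 4-fluorophenyl in place of 3-nitrophenyl changes it at all.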